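Swapping the ortho-hydroxyphenyl of compound 3 for benzothiazolyl

The source may report more compounds than this note shows. Statements on the series, on what has been measured and on what is new or still open speak of the compounds shown alone.

Compound 3 `Nc1ccc(S(=O)(=O)N2CCN(c3ncc(C(O)(C(F)(F)F)C(F)(F)F)cc3-c3ccccc3O)CC2)cn1` is measured in an ADME assay (liver) for metabolic stability, with Liver microsome (Rattus norvegicus) as the target, using microsomes and NADPH, with a stated time of 30 min, tested at 1 uM (a higher number here means faster removal of the compound, a lower number slower removal), at 125 mL.min-1.g-1. For the measured compounds named here, only one other full number exists in this assay: compound 2 `Nc1ccc(S(=O)(=O)N2CCN(c3ncc(C(O)(C(F)(F)F)C(F)(F)F)cc3C#CCO)CC2)cn1` gives 65 mL.min-1.g-1, and the step of a 1.9-fold higher number from compound 2 to compound 3 (0.28 log units; within the scatter) means the two cannot be told apart. Compound 1 `COc1cc(C(O)(C(F)(F)F)C(F)(F)F)cnc1N1CCN(S(=O)(=O)c2ccc(N)nc2)CC1` returns a limit in this assay, < 14 mL.min-1.g-1, which is the limit of < 14 mL.min-1.g-1 in this assay, at which 1 of the 3 values shown sits. From that limit the steps of an at least 4.6-fold higher number from compound 1 to compound 2 (0.66 log units; beyond the scatter) and an at least 8.9-fold higher number from compound 1 to compound 3 (0.95 log units; beyond the scatter) show that both replacements of the methoxy group raised clearance.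

Compound 4 `Nc1ccc(S(=O)(=O)N2CCN(c3ncc(C(O)(C(F)(F)F)C(F)(F)F)cc3-c3ccc4scnc4c3)CC2)cn1` differs from compound 3 in one place: 1,3-benzothiazol-5-yl in place of 2-hydroxyphenyl on an aromatic carbon. Going by the values given here, the steps that bear on this position are the two from compound 1, both clearly upward, and the one from compound 2 to compound 3, which stays inside the scatter. Among the compounds with values here, nothing among the measured compounds separates a hydroxyphenyl from a benzothiazolyl group at this carbon, so the expected step of a 1.3-fold higher number from compound 3 to compound 4 (0.11 log units; within the scatter) is none beyond the scatter, with a slight lean upward. Compound 4 is therefore estimated at 160 mL.min-1.g-1 in this assay, between 70 mL.min-1.g-1 and 350 mL.min-1.g-1.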

Compound 4, intrinsic clearance in microsomes: 147 mL.min-1.g-1
Beside the measured number, compound 4's estimate is 1.1-fold (0.04 log units) above it; the range from low to high includes it.
By their numbers in this assay, from the lowest: compounds 2, 3 and 4 (each within the scatter of the next, the first and the last beyond it). At a limit, below all of these: compound 1.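

In this assay, for the compounds shown here, the 1,3-benzothiazol-5-yl group has no hydrogen-bond donor, yet the change from 2-hydroxyphenyl gives only a 1.2-fold higher number from compound 3 to compound 4 (0.07 log units; within the scatter), while the change from the 3-hydroxyprop-1-yn-1-yl group gives a 2.3-fold higher number from compound 2 to compound 4 (0.35 log units; beyond the scatter), the first modest step beyond the scatter between two full numbers at this carbon. Replacing methoxy with 1,3-benzothiazol-5-yl gives an at least 10-fold higher number from compound 1 to compound 4 (1.02 log units; beyond the scatter), the largest step yet at this position, though still a bound rather than a measured size. Compound 1 returns a limit and not a number: the limit of < 14 mL.min-1.g-1 in this assay, at which 1 of the 4 values shown sits.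

On these data alone, whether any other group at this carbon could bring the number back towards that of compound 1, such as an amine, a carboxylic acid or a longer ether chain, remains open. So does how an unsubstituted phenyl would compare with the two aromatic groups shown.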